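The source may hold more compounds than are shown below. What is called first, only, known or untested is meant among the compounds shown, and "the series" means these compounds.

Compound 1 `CC(C)=CCC/C(C)=C/COc1cc(=O)n(CCCO)c2c1CC(CC=C(C)C)C(C)(C)C2`: 18.4%
Compound 2 `CC(C)=CCC1Cc2c(OC(=O)Nc3ccccc3F)cc(=O)n(CCCO)c2CC1(C)C`: 0%
Compound 3 `CC(C)=CCC1Cc2c(OC(=O)Nc3ccc(Cl)c(Cl)c3)cc(=O)n(CCCO)c2CC1(C)C`: 1.8%

Within the data shown here, in a functional assay on PANC-1 cells (Homo sapiens) for inhibition, read by MTT assay, with a stated time of 24 h, tested at 10 uM (a higher number here means more inhibition at the concentration tested (going by the name of the read-out), a lower number less inhibition), compound 1 stands highest of the three numbers measured so far; compound 3 is nearest and compound 2 furthest, both beyond the scatter. Both measured steps, a number 18.4 percentage points lower from compound 1 to compound 2 (beyond the scatter) and a number 16.6 percentage points lower from compound 1 to compound 3 (beyond the scatter), exchange the 3,7-dimethylocta-2,6-dien-1-yl group on the ring oxygen for a carbamoyl group, and neither touches the saturated chain carbon. Compound 4 `CC(C)=CCC/C(C)=C/COc1cc(=O)n(CCCO)c2c1CC(C/C=C(\C)CCC=C(C)C)C(C)(C)C2` keeps the ether of compound 1 and differs from it only by 3-methylbut-2-en-1-yl in place of hydrogen on a saturated chain carbon bound to a double-bonded chain carbon. Among the measured compounds shown here, no measured step bears on that place, so no direction can be argued from the data; the expected step of a number 0.4 percentage points lower from compound 1 to compound 4 (within the scatter) is none beyond the scatter. Compound 4 is therefore estimated at 18%, within 4% to 34%.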

Compound 4, a percentage reported as inhibition, at one concentration (the size of the read-out at that concentration, not a potency): 3.1%
Beside the measured number, compound 4's estimate is 14.9 percentage points above it; the measured number lies below the stated range.
By their numbers in this assay, from the lowest: compounds 2, 3 and 4 (each within the scatter of the next); then compound 1.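

In this assay, the saturated chain carbon bound to a double-bonded chain carbon proves sensitive: 3-methylbut-2-en-1-yl in place of hydrogen there gives a number 15.3 percentage points lower from compound 1 to compound 4 (beyond the scatter). Keeping the 3,7-dimethylocta-2,6-dien-1-yl ether on the ring oxygen therefore does not by itself preserve the read-out, and a change elsewhere on the shared core can also lower it. No available evidence accounts for this step.

Open, from the compounds shown here alone, is whether a methyl group or a chain ending in an amine at that place would also lower the number. Also open, going by these compounds, is how the same 3-methylbut-2-en-1-yl addition would act with a carbamoyl group on the ring oxygen.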